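The compounds below may be only part of what the source reports. "The series", "measured", "known", "first", "only" and "open" are said of these compounds alone.

Compounds with a measured value in a functional assay on MT4 cells (Homo sapiens) for antiproliferative activity, read by MTT assay, with a stated time of 96 h; a lower number here means that less compound is needed, a higher number that more compound is needed for the effect:
Compound 1 `Cn1cc(/C=C(\C#N)S(C)(=O)=O)c2ccccc21` gives > 100000 nM, a limit of the assay rather than a number.
Compound 2 `COC(=O)/C(=C\c1c[nH]c2ccccc12)S(=O)(=O)c1ccccc1` gives > 100000 nM, also a limit.
Compound 3 `Cc1[nH]c2ccccc2c1/C=C(\C#N)S(C)(=O)=O` gives > 100000 nM, again a limit.

Compound 3 thus stands where the other two stand: all three values shown rest at the limit of > 100000 nM in this assay, at which 3 of the 3 values shown sit, and no number separates any of them. Going by the values given here, no step between measured compounds that differ in one place is available in this set, so there is no measured step to lean on.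

Compound 4 `CS(=O)(=O)/C(C#N)=C/c1c[nH]c2ccccc12` is the compound still to be measured in this assay. It differs from compound 3 by hydrogen in place of methyl on an aromatic carbon. Among the compounds with values here, with every value shown resting on the limit of > 100000 nM in this assay, at which 3 of the 3 values shown sit, and no measured step for a change of this kind, no step beyond the scatter is expected in either direction from compound 3 to compound 4. The expected step from compound 3 to compound 4 is a number no higher from compound 3 to compound 4 (the limit leaves the size open). Compound 4 is therefore estimated at about 100000 nM, in the range 30000 nM to 300000 nM, with a strong chance that the assay again reports only a limit.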

Compound 4, half-maximal effective concentration: > 100000 nM
Compound 4: no number, only a limit (the forecaster's own chance of this, stated with the estimate: 85%); the middle value sits exactly at the limit.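

No step can be read from compound 3 to compound 4 or from compound 1 to compound 4, since each pair rests on limits alone: the limit of > 100000 nM in this assay, at which 4 of the 4 values shown sit.

The compounds shown leave open whether any change to the shared core yields a number in this assay, and so what either methyl contributes.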